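Replacing the Aryl on the Sulfonyl Sulfur of Compound 1

A few compounds are considered here, and "the series" means these few. Any claim that something is new, unique, unknown or untested is made for them only; others in the source may bear on it.

Compound 1 `Cn1c(=O)c(S(=O)(=O)c2ccc([N+](=O)[O-])cc2F)cc2cnc(Nc3ccc4[nH]ccc4c3)nc21` gives 400 nM in a functional assay on DU-145 cells (Homo sapiens) for inhibition, read by trypan blue exclusion, with a stated time of 72 h; a higher number here means a weaker inhibitor, a lower number a stronger inhibitor.
Compound 2 `Cn1c(=O)c(S(=O)(=O)c2ccc(F)cc2)cc2cnc(Nc3ccc4[nH]ncc4c3)nc21` gives 5000 nM in this assay.
Compound 3 `Cn1ccc2cc(Nc3ncc4cc(S(=O)(=O)c5ccc(Cl)cc5Cl)c(=O)n(C)c4n3)ccc21` gives 750 nM in this assay.

Among these three, compound 1 has the lowest number. Compound 3 sits nearest to it, and the two numbers lie within the scatter of each other, so nothing can be said about which of them is the stronger inhibitor. Compound 2 stands furthest away, with a number beyond the scatter, and is therefore the weaker inhibitor of that pair. Every one of the three differs from the others in more than one place, so no single change can be read from them.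

Compound 4 `COc1ccc(S(=O)(=O)c2cc3cnc(Nc4ccc5[nH]ccc5c4)nc3n(C)c2=O)cc1` has not yet been measured. It keeps the core of compound 1 and differs from it only in the group on the sulfonyl sulfur: 4-methoxyphenyl in place of 2-fluoro-4-nitrophenyl on a sulfonyl sulfur. Among the measured compounds shown here, since no step between measured compounds separates a single change of this kind, the direction is uncertain. A moderate step towards a higher number is expected, a 2.5-fold higher number from compound 1 to compound 4 (0.40 log units; beyond the scatter), given that compound 2 and compound 3 both show higher numbers than compound 1 with other groups on that sulfur. Compound 4 is accordingly estimated at 1000 nM, within a range of 300 nM to 4000 nM.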

Compound 4, half-maximal inhibitory concentration: 500 nM
Compound 4: middle estimate off by 2.0-fold (0.30 log units), on the high side; measured number inside the range.
By their numbers in this assay, from the lowest: compounds 1, 4 and 3 (each within the scatter of the next); then compound 2.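

Among the compounds shown here, this is the first single change on the sulfonyl sulfur that can be read in this assay: with the core of compound 1 kept, 4-methoxyphenyl in place of 2-fluoro-4-nitrophenyl gives a 1.3-fold higher number from compound 1 to compound 4 (0.10 log units; within the scatter), so the two groups cannot be told apart in this assay. For the compounds shown here, the two groups share only one six-membered aromatic ring of carbon only, since the fluorine and the nitro group leave and a methoxy group enters, so for this pair neither the fluorine nor the nitro group is needed for a number of this size. Nothing available here gives a reason for this result.

As far as these compounds go, compound 2 and compound 3 differ from compound 1 and compound 4 in more than one place, so those comparisons cannot be read, and it stays open how much of the higher number of compound 2 belongs to the group on the sulfur. Every compound shown carries a substituted phenyl on that sulfur, which leaves open how a plain alkyl such as methyl, or a phenyl bearing an amine or a carboxylic acid, would fare there.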